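Compound 3 to compound 4: tert-butyl for cyclohexyl

The source may hold more compounds than are shown below. What is called first, only, known or untested is meant among the compounds shown, and "the series" means these compounds.

In a functional assay on HT-29 cells (Homo sapiens) for inhibition, read by sulforhodamine B assay, with a stated time of 48 h (a higher number here means a weaker inhibitor of growth, a lower number a stronger inhibitor of growth), compound 1 `c1ccc(-c2ccc(NC3=NCCO3)cc2)cc1` gives 5800 nM and compound 2 `c1cc(OC2CCCC2)ccc1NC1=NCCO1` gives 16100 nM while compound 3 `O=C(CCl)NC(=O)Nc1ccc(C2CCCCC2)cc1` gives 2300 nM as the lowest number of the three. For the measured compounds named here, the gaps from compound 3 to both others lie beyond the scatter, and its core differs from the one shared by compound 1 and compound 2.

Compound 4 `CC(C)(C)c1ccc(NC(=O)NC(=O)CCl)cc1` keeps the core of compound 3 and carries tert-butyl in place of cyclohexyl on an aromatic carbon. Going by the values given here, no step has been measured on this core, so the evidence is indirect. Among the compounds with values here, the only measured exchange of a group on an aromatic carbon is a 2.8-fold higher number from compound 1 to compound 2 (0.44 log units; beyond the scatter) with cyclopentyloxy in place of phenyl. That step is modest, though beyond the scatter, and it sits on the other core.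

Within the data shown here, a small move toward a higher number is therefore expected in this assay, since the starting point is the lowest value so far and the one measured exchange moved upward by a modest amount. The expected change is a 1.4-fold higher number from compound 3 to compound 4 (0.14 log units; within the scatter) and it may well stay within the scatter. Compound 4 is estimated at 3200 nM with an expected range from 1300 nM to 7500 nM as the working figure.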

Compound 4, concentration for 50% growth inhibition: 3300 nM
The estimate for compound 4 lay 1.0-fold (0.01 log units) below the measured number; the range from low to high includes it.
By their numbers in this assay, from the lowest: compounds 3, 4 and 1 (each within the scatter of the next, the first and the last beyond it); then compound 2.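

In this assay, for the compounds shown here, the exchange on an aromatic carbon para to a group of 8 heavy atoms gives a 1.4-fold higher number from compound 3 to compound 4 (0.16 log units; within the scatter), and this is the first step that can be read on the core of compound 3. With tert-butyl in place of cyclohexyl, the six-membered non-aromatic ring gives way to an open group with fewer heavy atoms, and the read-out does not separate the two, so on this core and for this pair a ring at this position is not needed to keep the number within the scatter. Going by these compounds alone, the only other exchange on an aromatic carbon, a 2.8-fold higher number from compound 1 to compound 2 (0.44 log units; beyond the scatter), lies on the other core and involves different groups, so it says nothing about this position; no measurement at hand accounts for how closely the two groups read here.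

The compounds shown leave open how far this tolerance extends, as the pair covers only two carbon-only groups and gives no reading for an amine, a carboxylic acid or a longer alkyl chain at this position. Within the data shown here, also open is how any one group would read on both cores, as no pair spanning them differs in one place.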